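Replacing a Fused Ring Amide with a Cyclohexylmethyl Urea

The compounds below may be only part of what the source reports. "The series", "measured", "known", "first", "only" and "open" are said of these compounds alone.

Compound 1 `COc1cc(NC(C)CCCNC(=O)NCc2ccncc2)c2ncccc2c1` gives 10000 nM in an ADME assay on WI-38 cells (Homo sapiens), read by MTT assay, with a stated time of 72 h; a lower number here means a stronger inhibitor, a higher number a weaker inhibitor. Compound 2 `COc1cc(NC(C)CCCNC(=O)n2nnc3ccccc32)c2ncccc2c1` reaches only a limit of this assay, > 100000 nM. The step of an at least 10-fold higher number from compound 1 to compound 2 (1.00 log units; beyond the scatter) therefore rests on that limit (the limit of > 100000 nM in this assay, at which 1 of the 2 values shown sits). Compound 3 `COc1cc(NC(C)CCCNC(=O)NCC2CCCCC2)c2ncccc2c1` differs from compound 2 by a group of 8 heavy atoms (7 carbon, 1 nitrogen; one six-membered non-aromatic ring of carbon only) in place of a group of 9 heavy atoms (6 carbon, 3 nitrogen; one five-membered aromatic ring with 3 hetero atoms, one six-membered aromatic ring of carbon only), on a carbonyl carbon. For the measured compounds named here, only the single measured step at this carbonyl carbon bears on the change, and it was at least modest in size. The expected step is an at least 5.0-fold lower number from compound 2 to compound 3 (0.69 log units; beyond the scatter), toward a lower number. Compound 3 is estimated at 20000 nM, within a range of 5000 nM to 100000 nM.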

Compound 3, half-maximal inhibitory concentration: > 100000 nM
Compound 3: no number, only a limit (the forecaster's own chance of this, stated with the estimate: 30%); middle value at least 5.0-fold (0.69 log units) away from the limit.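

In this assay, cyclohexyl in place of pyridin-4-yl on the saturated chain carbon bound to an amide-type nitrogen gives an at least 10-fold higher number from compound 1 to compound 3 (1.00 log units; beyond the scatter), so the urea alone does not carry the reading of compound 1. Compound 3 gives > 100000 nM, which is a limit and not a number. The step between compound 2 and compound 3 cannot be read, because both sit at that limit: the limit of > 100000 nM in this assay, at which 2 of the 3 values shown sit.

The compounds shown leave open how a phenyl or pyridin-3-yl ring would read in place of pyridin-4-yl. They also leave open whether an amine on the cyclohexyl ring would bring a readable number.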